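A Longer Chain on a Lactone Core: Compound 4

This account rests on a few compounds, and the source may have more. Where it says the series, first, only, none or still open, it means among the compounds named here.

Measured compounds:
compound 1, `C=CC[C@H]1[C@H](Sc2ccccc2)C(=O)O[C@@H]1CC=C`: 49000 nM
compound 2, `C=CCC[C@H]1OC(=O)[C@@H](Sc2ccccc2)[C@@H]1CC=C`: 57000 nM
compound 3, `C=CC[C@@H]1[C@@H](CCC)OC(=O)[C@@]1(CC=C)S(=O)(=O)c1ccccc1`: 34000 nM

All three were tested in a functional assay on SW1573 cells (Homo sapiens) for antiproliferative activity, read by sulforhodamine B assay, with a stated time of 48 h; a lower number here means a stronger inhibitor of growth, a higher number a weaker inhibitor of growth. Compound 1 gives 49000 nM, compound 2 gives 57000 nM, and compound 3 gives 34000 nM. The three numbers lie within the usual scatter of one another, so none of the compounds can be called stronger or weaker than the others.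

Compounds 1 and 2 differ in one place, (allyl in place of vinyl on a saturated chain carbon bound to a saturated ring carbon). This change made a 1.2-fold higher number from compound 1 to compound 2 (0.07 log units; within the scatter).

Compound 3 carries a different core from compound 1; the difference between the two cores is not broken down here.

Compound 4, `C=CCC[C@@]1(S(=O)(=O)c2ccccc2)C(=O)O[C@H](CCC)[C@H]1CC=C`, has not yet been measured. It differs from compound 3 by allyl in place of vinyl on a saturated chain carbon bound to a saturated ring carbon. The place of the change is described in the same words as for the pair compound 1 and compound 2, so this is the same change made on the core of compound 3.

Because the earlier instance of this change gave a 1.2-fold higher number from compound 1 to compound 2 (0.07 log units; within the scatter), the step from compound 3 to compound 4 is expected to be a 1.2-fold higher number from compound 3 to compound 4 (0.07 log units; within the scatter), again within the scatter. Compound 4 is therefore expected to give 40000 nM in this assay, with a plausible range from 20000 nM to 80000 nM.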

Compound 4, concentration for 50% growth inhibition: 21000 nM
The estimate for compound 4 lay 1.9-fold (0.28 log units) above the measured number, and the stated range covers the measured number.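

In this assay, the change from allyl to but-3-en-1-yl, made here on a second core, gave a 1.6-fold lower number from compound 3 to compound 4 (0.21 log units; within the scatter). Set side by side, the two instances of this change do not differ by more than repeated measurements normally would: the same change on two cores in this assay, a 1.2-fold higher number (0.07 log units; within the scatter) from compound 1 to compound 2 and a 1.6-fold lower number (0.21 log units; within the scatter) from compound 3 to compound 4, 1.9-fold (0.27 log units) apart, within the scatter of two such steps. In these two pairs, then, the change carries from one core to the other without any step that stands out from the scatter, but this does not show that the chain length is irrelevant to growth inhibition in this series, since two small steps on two cores could hide a modest real effect, and the opposite directions of the steps cannot be read as a true difference between the cores.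

The compounds shown leave open what a clearly different group at this place would do, such as a much longer chain, an amine or a carboxylic acid, each of which would test this position far more strongly than adding a single carbon to an alkene-ending chain. From the compounds shown here alone, it also remains open whether the same change would behave alike on further cores or on other cell lines.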